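A Bromine for a Methyl in Weak Cytotoxic Ureas

The source may hold more compounds than are shown below. What is called first, only, known or untested is meant among the compounds shown, and "the series" means these compounds.

Compound 3 `Cc1ccc(C2CNC(=O)N2S(=O)(=O)c2ccc(C)cc2)cc1` stands at the edge of what a functional assay on A549 cells (Homo sapiens) for cytotoxicity (on this read-out lower numbers stand for stronger inhibition and higher numbers for weaker inhibition), can report: in this assay compound 3 gives > 302000 nM, which is a limit of the assay and not a number. Of the two other compounds on the same core, compound 1 `Cc1ccc(C2CNC(=O)N2S(=O)(=O)c2ccc(Cl)cc2)cc1` gives 266000 nM in this assay. Compound 2 `Cc1ccc(S(=O)(=O)N2C(=O)NCC2c2ccccc2)cc1` returns > 316000 nM in this assay, again a limit. The move to compound 4 `Cc1ccc(S(=O)(=O)N2C(=O)NCC2c2ccc(Br)cc2)cc1` is bromo in place of methyl on an aromatic carbon. Going by the values given here, two measured steps concern an exchange on an aromatic carbon. The nearest is an at least 1.1-fold higher number from compound 1 to compound 3 (0.05 log units; that floor lies within the scatter), a methyl in place of chloro, and it rests on (the limit of > 302000 nM in this assay, at which 1 of the 3 values shown sits). The step that the two limits leave unreadable from compound 2 to compound 3 cannot be read, as the limit of > 302000 nM in this assay, at which 1 of the 3 values shown sits, and the limit of > 316000 nM in this assay, at which 1 of the 3 values shown sits, show. Among the compounds with values here, with the only readable step sitting at a limit, the expectation is for no change beyond the scatter, and the result for compound 4 is likely to be a limit once more. Compound 4 is therefore estimated at about 290000 nM in this assay, expected between 100000 nM and 700000 nM, an expected step of an at least 1.0-fold lower number from compound 3 to compound 4 (0.01 log units; that floor lies within the scatter).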

Compound 4, half-maximal inhibitory concentration: 67000 nM
Compound 4: middle estimate off by 4.3-fold (0.64 log units), on the high side; measured number below the stated range.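

In this assay, this aromatic carbon gives the first exchange whose effect lies beyond the scatter: going from 4-methylphenyl to 4-bromophenyl brings an at least 4.5-fold lower number from compound 3 to compound 4 (0.65 log units; beyond the scatter), and bromo in place of hydrogen at the same carbon brings an at least 4.7-fold lower number from compound 2 to compound 4 (0.67 log units; beyond the scatter). Compound 3 is a limit of the assay, so the step from methyl gives only a floor for the true size: the limit of > 302000 nM in this assay, at which 1 of the 4 values shown sits. Compound 2 is also a limit of the assay, so the step from hydrogen is likewise only a floor: the limit of > 316000 nM in this assay, at which 1 of the 4 values shown sits.

The compounds shown leave open how far either step truly reaches, and whether the lower number is particular to bromo. An amine, a carboxylic acid or a methoxy group on this aromatic carbon would test whether other groups there also lower the number.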